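The source may report more compounds than this note shows. Statements on the series, on what has been measured and on what is new or still open speak of the compounds shown alone.

Measured compounds:
Compound 1, `CN1CCN(c2nc(-c3ccc(Cl)cc3)nc3[nH]cnc23)CC1`, gives 6.2% in an assay on cells for displacement of a labelled ligand from adenosine receptor A2b (Homo sapiens), read by scintillation counting and radioligand binding, with a stated time of 30 min, tested at 10 uM; on this read-out lower numbers stand for less inhibition and higher numbers for more inhibition at the one concentration tested (going by the name of the read-out).
Compound 2, `CN1CCN(c2nc(-c3cccc(Cl)c3)nc3c2ncn3C)CC1`, gives 19.2% in this assay.

Compound 1 stands lowest of the two numbers in this assay; its nearest neighbour is compound 2, whose number lies higher by a gap beyond the usual scatter. Within the data shown here, no pair of measured compounds differs in only one place, so no single step within the measured set is available to lean on; the two values simply show that compound 1 sits lower than compound 2.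

Compound 3, `CN1CCN(c2nc(-c3cccc(O)c3)nc3[nH]cnc23)CC1`, has not yet been measured in this assay. It differs from compound 1 in one place: 3-hydroxyphenyl in place of 4-chlorophenyl on an aromatic carbon.

Among the measured compounds shown here, with no measured step of this kind to guide the expectation, compound 3 is expected to stay near the low end seen so far, and the expected step of a number 3.8 percentage points higher from compound 1 to compound 3 (within the scatter) is one that might lie within the scatter or amount to a modest rise. The estimate for compound 3 in this assay is 10%, with a range from -5% to 30%.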

Compound 3, a percentage reported as inhibition, at one concentration (the size of the read-out at that concentration, not a potency): 27%
Beside the measured number, compound 3's estimate is 17 percentage points below it, and the stated range covers the measured number.
By their numbers in this assay, from the lowest: compound 1; then compounds 2 and 3 (each within the scatter of the next).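

In this assay, among these compounds, putting 3-hydroxyphenyl in place of 4-chlorophenyl on the aromatic carbon between two ring nitrogen atoms gives a number 20.8 percentage points higher from compound 1 to compound 3 (beyond the scatter), the first single change in this set that can be read and the first sign that the number responds to the aryl group at this position. The step is modest and describes the size of the read-out at one concentration, not a potency, and it combines two changes on the phenyl ring: chlorine gives way to a hydroxyl group, and the numbered place of the substituent moves from 4 to 3, so the step cannot assign the rise to either one alone. No measurement shown here explains the rise.

The compounds shown leave open whether the rise belongs to the hydroxyl group itself, a question that 4-hydroxyphenyl, 3-methoxyphenyl, 3-aminophenyl or plain phenyl at the same carbon would address on the core of compound 1. They also leave open whether a larger group at this carbon, such as a pyridine ring or a benzyl group, would carry the number further.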